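The source may report more compounds than this note shows. Statements on the series, on what has been measured and on what is new or still open speak of the compounds shown alone.

Measured so far:
compound 1 `O=C(NCc1cccs1)c1cccc(O)c1O`, > 40000 nM
compound 2 `O=C(NCc1ccc(-c2cccs2)cc1)c1cccc(O)c1O`, 15000 nM

In an ADME assay on NCI-H630 cells (Homo sapiens) for cytotoxicity, read by MTT assay, with a stated time of 72 h (on this read-out higher numbers stand for lower toxicity in this test and lower numbers for higher toxicity in this test), compound 1 gives > 40000 nM, which is a limit of the assay and not a number. Compound 2 gives 15000 nM in this assay. Compound 1 thus stands at the top of the measured range, at the limit of > 40000 nM in this assay, at which 1 of the 2 values shown sits. The step to compound 3 `O=C(NCC1CCCCC1)c1cccc(O)c1O` keeps the core of compound 1 and alters only the amide substituent: cyclohexyl in place of thiophen-2-yl on a saturated chain carbon bound to an amide-type nitrogen. Among the compounds with values here, no measured pair shows this change. In this assay no step beyond the scatter is expected, a step that the limit leaves unreadable from compound 1 to compound 3, with a limit again likely. Compound 3 is estimated at 45000 nM, within 15000 nM to 150000 nM.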

Compound 3, half-maximal cytotoxic concentration: 21000 nM
Beside the measured number, compound 3's estimate is 2.1-fold (0.33 log units) above it; measured number inside the range.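

Cyclohexyl in place of thiophen-2-yl on a saturated chain carbon bound to an amide-type nitrogen gives an at least 1.9-fold lower number from compound 1 to compound 3 (0.27 log units; that floor lies within the scatter) in this assay. Compound 3 gives 21000 nM, so this place can hold a group that yields a number rather than a limit. For compound 1 the reading remains a limit of the assay and not a number, so the true size of the step cannot be read: the limit of > 40000 nM in this assay, at which 1 of the 3 values shown sits.

As far as these compounds go, whether a piperidine ring, a carboxylic acid or a longer chain at this place would shift the reading in this assay stays open. From the compounds shown here alone, whether the step itself exceeds the usual scatter also stays open.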